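The source may hold more compounds than are shown below. What is called first, only, known or untested is meant among the compounds shown, and "the series" means these compounds.

Of the compounds shown here, three sharing one core have been read in a functional assay on ileum (Cavia porcellus) for antagonist activity, with a stated time of 30 s; on this read-out lower numbers stand for stronger inhibition and higher numbers for weaker inhibition: compound 1 (`CCCc1ccccc1OCCCOc1ccc2c(=O)cc(C(=O)O)oc2c1CCC`), compound 2 (`CCCc1ccccc1OCC(O)COc1ccc2c(=O)cc(C(=O)O)oc2c1`) and compound 3 (`CCCc1ccccc1OCC(O)COc1ccc2c(=O)cc(C(=O)O)oc2c1CCC`). Compound 3 gives 0.044 ug/mL, the lowest of the three numbers, while compound 1 gives 0.18 ug/mL and compound 2 gives 2 ug/mL. The next compound, compound 4 (`CCCc1c(OCc2ccccc2)cccc1OCC(O)COc1ccc2c(=O)cc(C(=O)O)oc2c1CCC`), differs from compound 3 by a single change: benzyloxy in place of hydrogen on an aromatic carbon. Benzyloxy thus takes the place of hydrogen on an aromatic carbon.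

For the measured compounds named here, two measured steps bear on this change, though only indirectly. The hydroxy step, a 4.1-fold lower number from compound 1 to compound 3 (0.61 log units; beyond the scatter), was modest, and the propyl step, a 45-fold lower number from compound 2 to compound 3 (1.66 log units; beyond the scatter), was large. The propyl step shows that one added group on an aromatic carbon can shift the number strongly, but it lies at a different place. Going by the values given here, no measured compound carries benzyloxy, so the direction rests on little. With compound 3 already at 0.044 ug/mL, a modest move to a higher number is expected in this assay. The expected step is a 1.8-fold higher number from compound 3 to compound 4 (0.26 log units; within the scatter). For compound 4 the estimate is 0.08 ug/mL, with an expected range from 0.015 ug/mL to 0.4 ug/mL.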

Compound 4, half-maximal inhibitory concentration: 1 ug/mL
Beside the measured number, compound 4's estimate is 13-fold (1.10 log units) below it, and the stated range ends below it.
By their numbers in this assay, from the lowest: compound 3; then compound 1; then compounds 4 and 2 (each within the scatter of the next).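

In this assay, benzyloxy on this aromatic carbon, ortho to a propyl group, gives a 23-fold higher number from compound 3 to compound 4 (1.36 log units; beyond the scatter), so this ring position, which carries only hydrogen in compounds 1 to 3, strongly affects the read-out. Both earlier steps ended at compound 3 with a lower number, whereas this is the first step shown that leads away from compound 3 to a higher one, and it leaves compound 4 within the scatter of compound 2. No measurement shown gives a reason for this large loss of inhibition.

With benzyloxy as the only group shown at this position, the compounds cannot separate the effect of the oxygen link from that of the added benzene ring. From the compounds shown here alone, it remains open whether a methoxy or hydroxy group on the same carbon would keep the number near that of compound 3.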